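Demethylation at the ring nitrogen of a fused amine

The compounds below may be only part of what the source reports. "The series", "measured", "known", "first", "only" and "open" are said of these compounds alone.

Compound 2, `CN1CC[C@@H]2CC[C@H](O)C[C@@H]21`: > 300000 nM
Compound 1, `CCO[C@H]1CC[C@H]2CCN(C)[C@H]2C1`: > 300000 nM

In an assay on HEK293 cells for antagonist activity at Nicotinic acetylcholine receptor alpha-4/beta-2 (Mus musculus), read by FLIPR, using a membrane potential dye (a lower number here means a stronger inhibitor, a higher number a weaker inhibitor), compound 2 gives > 300000 nM, which is a limit of the assay and not a number. Compound 1 likewise gives > 300000 nM, also a limit. The change hydrogen in place of ethyl on an oxygen on a saturated carbon, a step that the two limits leave unreadable from compound 1 to compound 2, is therefore unreadable, since both values sit at the limit of > 300000 nM in this assay, at which 2 of the 2 values shown sit. Compound 3 `O[C@H]1CC[C@H]2CCN[C@H]2C1` differs from compound 2 by hydrogen in place of methyl on an amine nitrogen in a ring. Among the compounds with values here, no measured step bears on this change, and compound 2 itself stands only at a limit. Compound 3 is expected at 300000 nM, in a range from 100000 nM to 1000000 nM. The estimated step of a number no higher from compound 2 to compound 3 (the limit leaves the size open) is expected to show no change readable beyond the limit.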

Compound 3, half-maximal inhibitory concentration: > 100000 nM
Compound 3: a limit, no number; the forecaster's own chance of this, stated with the estimate: 85%; the middle value lies beyond the limit too.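

Compound 2 and compound 3 both stand only at limits, so no step can be read between them. The compounds shown leave open whether any change to the shared core gives a readable value in this assay.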